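The source may report more compounds than this note shows. Statements on the series, on what has been measured and on what is new or still open speak of the compounds shown alone.

Compounds 1, 2 and 3 share one core and differ in the group on a saturated chain carbon bound to an aromatic nitrogen. The question here is how they behave in an ADME assay on LLC-PK1 cells (Sus scrofa) for permeability, with a stated time of 3 h, tested at 1 uM; a higher number here means that the compound crosses the layer faster, a lower number that the compound crosses the layer more slowly. For compound 1 `N#Cc1ccc(Cn2c3c(c(O)c(C(=O)NCC(=O)O)c2=O)COCC3)c(F)c1` the entry reads "not determined" (no result reported), so it offers no guide. Compound 2 `O=C(O)CNC(=O)c1c(O)c2c(n(Cc3ccc(C(F)(F)F)nc3)c1=O)CCOC2` gives < 1.7 10^-6 cm/s, which is a limit of the assay and not a number. The measured picture so far therefore comes down to the limit of < 1.7 10^-6 cm/s in this assay, at which 1 of the 2 values shown sits.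

Compound 3 `O=C(O)CNC(=O)c1c(O)c2c(n(Cc3nc4ccccc4s3)c1=O)CCOC2` has 1,3-benzothiazol-2-yl in place of 6-(trifluoromethyl)pyridin-3-yl on that same carbon: 1,3-benzothiazol-2-yl in place of 6-(trifluoromethyl)pyridin-3-yl on a saturated chain carbon bound to an aromatic nitrogen. Among the measured compounds shown here, no measured pair of compounds shows what a swap of this kind does, so no shift beyond the usual scatter is expected in this assay, in either direction. The expected change is a step that the limit leaves unreadable from compound 2 to compound 3. This expectation rests on compound 2 alone, whose < 1.7 10^-6 cm/s is again a limit. Compound 3 may well be reported only as a limit too. For compound 3 the expected apparent permeability is 1.5 10^-6 cm/s, with an estimated range from 0.6 10^-6 cm/s to 4 10^-6 cm/s.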

Compound 3, apparent permeability: < 2.1 10^-6 cm/s
Compound 3: only a limit was reported (the forecaster's own chance of this, stated with the estimate: 60%); the middle value lies beyond the limit too.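

In this assay, compound 2 gives < 1.7 10^-6 cm/s, which is a limit of the assay and not a number. Among the compounds shown here, compound 3 gives < 2.1 10^-6 cm/s, again a limit, so no step between compound 2 and compound 3 can be read. Still open, going by these compounds, is whether 1,3-benzothiazol-2-yl in place of 6-(trifluoromethyl)pyridin-3-yl changes how fast these compounds cross the layer.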